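Taking the Side Chain off Compound 3

The compounds below may be only part of what the source reports. "The series", "measured", "known", "first", "only" and "open" are said of these compounds alone.

In a functional assay on A-375 cells (Homo sapiens) for cytotoxicity, read by MTT assay, with a stated time of 72 h (on this read-out higher numbers stand for weaker inhibition and lower numbers for stronger inhibition), compound 1 `O=C1c2c[n+]([O-])c3ccccc3c2C(=O)c2c1c1ccccc1n2Cc1cn(CC(O)CO)nn1` gives 440 nM and compound 2 `O=C1c2c[n+]([O-])c3ccccc3c2C(=O)c2c1c1ccccc1n2CCN1CCCC1` gives 430 nM on the same core. Compound 3 `O=C1c2c[n+]([O-])c3ccccc3c2C(=O)c2c1c1ccccc1n2CCCCN1CCCCC1` reaches 190 nM as the lowest number of the three, which makes it the strongest inhibitor measured so far.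

Compound 4 `O=C1c2c[n+]([O-])c3ccccc3c2C(=O)c2[nH]c3ccccc3c21` is compound 3 with hydrogen in place of 4-(piperidin-1-yl)butyl on an aromatic nitrogen and so carries no side chain there. For the measured compounds named here, no measured compound lacks that side chain, so no step shows this change directly. The nearest guides are swaps of one side chain for another. One of them stays within the scatter (a 1.0-fold lower number from compound 1 to compound 2 (0.01 log units; within the scatter)) and two are modest (a 2.3-fold lower number from compound 1 to compound 3 (0.36 log units; beyond the scatter); a 2.3-fold lower number from compound 2 to compound 3 (0.35 log units; beyond the scatter)).

Those swaps suggest that this position shifts the number only moderately, yet removing the chain altogether is a larger change than any of them. Compound 3 sits lowest at 190 nM so a move towards a higher number, meaning weaker inhibition, is the more likely direction in this assay and it is expected to be modest. The expected step is a 2.9-fold higher number from compound 3 to compound 4 (0.46 log units; beyond the scatter) with real uncertainty around it. Estimated for compound 4 is a value of 550 nM with an expected range from 200 nM to 1500 nM in this comparison.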

Compound 4, half-maximal inhibitory concentration: 660 nM
For compound 4 the middle estimate is 1.2-fold (0.08 log units) below the measured one, within the range that was stated.
By their numbers in this assay, from the lowest: compound 3; then compounds 2, 1 and 4 (each within the scatter of the next).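

In this assay, the aromatic nitrogen can carry a bare hydrogen and the shared core keeps a number close to those of two of the side-chain compounds, since both of these steps stay within the scatter (a 1.5-fold higher number from compound 2 to compound 4 (0.19 log units; within the scatter); a 1.5-fold higher number from compound 1 to compound 4 (0.18 log units; within the scatter)). For the compounds shown here, the compounds therefore give no sign that 2-(pyrrolidin-1-yl)ethyl or (1-(2,3-dihydroxypropyl)-1H-1,2,3-triazol-4-yl)methyl does anything measurable here compared with hydrogen, whereas 4-(piperidin-1-yl)butyl is the one group that stands clear of hydrogen (a 3.5-fold higher number from compound 3 to compound 4 (0.54 log units; beyond the scatter)), making compound 3 the strongest inhibitor of the four. No measurement available here explains why that one chain stands apart.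

Compound 2 and compound 3 differ in both the length of the chain and the size of the amine ring, so the gain seen with compound 3 cannot yet be assigned to either feature. A 2-(piperidin-1-yl)ethyl or a 4-(pyrrolidin-1-yl)butyl group would separate those two features, and a plain butyl chain with no amine ring would show whether the chain alone is enough.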